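Swapping a cyclopropylmethyl for an oxan-4-yl group

The source may hold more compounds than are shown below. What is called first, only, known or untested is meant among the compounds shown, and "the series" means these compounds.

Measured so far:
compound 1 `CCCN(CCC)c1cccc2nc(N(C)c3c(C)cc(C)cc3C)c(=O)n(C)c12` gives > 1000 nM in an assay on HEK293 cells for displacement of a labelled ligand from corticotropin-releasing factor receptor 1 (Homo sapiens), read by scintillation proximity assay, with a stated time of 2 h; a higher number here means a weaker inhibitor, a lower number a stronger inhibitor
compound 2 `Cc1cc(C)c(Nc2nc3cccc(N(CC4CC4)CC4CC4)c3cc2C)c(C)c1` gives 75 nM in this assay

The value for compound 1 is a limit of this assay, not a number (the limit of > 1000 nM in this assay, at which 1 of the 2 values shown sits). Within the data shown here, compound 2 therefore holds the only numerical value shown. Compound 3 `Cc1cc(C)c(Nc2nc3cccc(N(CC4CC4)C4CCOCC4)c3cc2C)c(C)c1` differs from compound 2 in one place: oxan-4-yl in place of cyclopropylmethyl on a nitrogen on an aromatic ring. Among the measured compounds shown here, no measured pair shows this kind of change, so the expectation for compound 3 rests on compound 2 alone. A modest weakening is expected, with the step from compound 2 to compound 3 in this assay estimated as a 2.0-fold higher number from compound 2 to compound 3 (0.30 log units; within the scatter). Compound 3 is estimated at 150 nM, with a range from 40 nM to 600 nM.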

Compound 3, half-maximal inhibitory concentration: 90 nM
The estimate for compound 3 lay 1.7-fold (0.22 log units) above the measured number, within the range that was stated.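

In this assay, placing oxan-4-yl on this nitrogen instead of cyclopropylmethyl gives a 1.2-fold higher number from compound 2 to compound 3 (0.08 log units; within the scatter) and so leaves the two groups indistinguishable at this position. Compound 2 alone could not show that a six-membered ring carrying a hydrogen-bond acceptor can stand here without a change beyond the scatter.

Still open, as far as these compounds go, is how a piperidin-4-yl ring, which carries an amine, or a longer chain would fare on this nitrogen, and what replacing the remaining cyclopropylmethyl of compound 3 would do. Nothing shown explains this result.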